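The source may hold more compounds than are shown below. What is called first, only, known or untested is meant among the compounds shown, and "the series" means these compounds.

Working notes on the series. Among the measured compounds shown here, the shared core of compound 1 `O=C(O)c1cc(-c2cocn2)ccc1O` carries a five-membered aromatic ring on the aromatic carbon meta to the carboxy group and para to the hydroxy group; compound 2 `O=C(O)c1cc(-n2nccn2)ccc1O` and compound 3 `O=C(O)c1cc(-n2cncn2)ccc1O` vary only that ring. In a functional assay on the whole organism for inhibition, with Rattus norvegicus as the target, read by paw edema (a higher number here means that more compound is needed for the effect, a lower number that less compound is needed), compound 1 gives 110 mg/kg, compound 2 gives 150 mg/kg and compound 3 gives 200 mg/kg. The three numbers do not separate: the distance a 1.8-fold higher number from compound 1 to compound 3 (0.26 log units; within the scatter) and the distance a 1.3-fold higher number from compound 2 to compound 3 (0.12 log units; within the scatter) both sit within the scatter, so compound 3 cannot be set apart from either of the other two on these data. Compound 4 `O=C(O)c1cc(-n2cccn2)ccc1O` makes a change of the same kind: 1H-pyrazol-1-yl in place of 1H-1,2,4-triazol-1-yl on an aromatic carbon. For the measured compounds named here, three steps bear on it, each an exchange of one five-membered aromatic ring for another on that carbon, and each was small: a 1.4-fold higher number from compound 1 to compound 2 (0.13 log units; within the scatter), a 1.8-fold higher number from compound 1 to compound 3 (0.26 log units; within the scatter), a 1.3-fold higher number from compound 2 to compound 3 (0.12 log units; within the scatter). None reached beyond the scatter, so no step beyond the scatter is expected here either, in this assay , and the expected shift is a 1.1-fold lower number from compound 3 to compound 4 (0.05 log units; within the scatter). Compound 4 is therefore estimated to give 180 mg/kg in this assay , with a range from 90 mg/kg to 360 mg/kg.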

Compound 4, dose for half-maximal effect: 200 mg/kg
Beside the measured number, compound 4's estimate is 1.1-fold (0.05 log units) below it; the measured number falls inside the stated range.
By their numbers in this assay, from the lowest: compounds 1, 2, 3 and 4 (each within the scatter of the next).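

Exchanging a ring nitrogen of 1H-1,2,4-triazol-1-yl for a ring carbon in 1H-pyrazol-1-yl, at the aromatic carbon meta to the carboxy group and para to the hydroxy group, leaves the reading in this assay unresolved: no change at the digits printed from compound 3 to compound 4 (within the scatter). The comparisons with the other two rings also stay inside the noise, with a 1.3-fold higher number from compound 2 to compound 4 (0.12 log units; within the scatter) and a 1.8-fold higher number from compound 1 to compound 4 (0.26 log units; within the scatter), so the series now holds four five-membered aromatic rings at this position, differing in their hetero atoms, and none can be set apart from another on these data. Nothing at hand bears on why these rings read alike.

The compounds shown leave open whether anything other than a five-membered aromatic ring at this carbon, such as an amine, a carboxylic acid or a longer alkyl chain, would produce a step beyond the scatter. They also leave open how much the carboxy and hydroxy groups of the shared core contribute to the reading, since both stay fixed throughout.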